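This account rests on a few compounds, and the source may have more. Where it says the series, first, only, none or still open, it means among the compounds named here.

Compound 3 `COc1ccc(-c2cc(=O)c3c(OC)cc(OC)cc3n2S(=O)(=O)c2ccc(OC)cc2)cc1` stands at a limit in a functional assay on HepG2 cells (Homo sapiens) for antiproliferative activity, with a stated time of 72 h; a higher number here means that more compound is needed for the effect, a lower number that less compound is needed: in this assay compound 3 gives > 82700 nM, which is a limit and not a number. The two further values of the series are limits as well. In this assay compound 1 `COc1ccc(-c2cc(=O)c3c(OC)cc(OC)cc3n2Cc2ccccc2)cc1` gives > 17300 nM, a limit. In this assay compound 2 `COc1ccc(-c2cc(=O)c3c(OC)cc(OC)cc3n2S(=O)(=O)c2ccc(C#N)cc2)cc1` gives > 17200 nM, also a limit. Compound 3 therefore cannot be ranked against compound 1 or compound 2; all three sit at limits, compound 3 at the limit of > 82700 nM in this assay, at which 1 of the 3 values shown sits.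

Compound 4 `COc1ccc(-c2cc(=O)c3c(OC)cc(OC)cc3n2S(=O)(=O)c2ccc(Br)s2)cc1` differs from compound 3 by 5-bromothiophen-2-yl in place of 4-methoxyphenyl on a sulfonyl sulfur. Two measured steps reach compound 3: a step that the two limits leave unreadable from compound 1 to compound 3, and a step that the two limits leave unreadable from compound 2 to compound 3. The remaining step, a step that the two limits leave unreadable from compound 1 to compound 2, is equally unreadable. No change made so far on the group attached to the sulfonyl sulfur, or on the aromatic nitrogen, has produced a numbered value in this assay, so neither a direction nor a size can be read for the present change.

Compound 4 is accordingly expected to remain at or near the limit, with an estimate of 60000 nM in this assay, in the range 15000 nM to 200000 nM. The step of an at least 1.3-fold lower number from compound 3 to compound 4 (0.13 log units; that floor lies within the scatter) is expected to be none beyond the scatter.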

Compound 4, half-maximal effective concentration: > 48200 nM
Compound 4 ended at the assay's limit (the forecaster's own chance of this, stated with the estimate: 80%); the middle value does not contradict the limit.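

Compound 1, compound 2, compound 3 and compound 4 all stand at limits in this assay, and no step among these four compounds can be read. The compounds shown leave open whether any group on the sulfonyl sulfur or on the aromatic nitrogen gives a numbered value in this assay, and the direction and size of any such change.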